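A Larger Amide Substituent for the Shared Core

The source may hold more compounds than are shown below. What is called first, only, known or untested is meant among the compounds shown, and "the series" means these compounds.

Compound 2 `CC(C)c1onc(-c2c(Cl)cccc2Cl)c1COc1ccc(N(C)Cc2cccc(C(=O)NS(C)(=O)=O)c2)c(C(F)(F)F)n1` gives 20 nM in a functional assay on HEK293 cells for agonist activity at Bile acid receptor (Homo sapiens), read by a luciferase reporter (a lower number here means that less compound is needed, a higher number that more compound is needed for the effect), the higher of the two numbers shown, while compound 1 `CC(C)c1onc(-c2c(Cl)cccc2Cl)c1COc1ccc(N(C)Cc2cccc(C(=O)O)c2)c(C(F)(F)F)n1` gives 6 nM. Among the compounds with values here, the only step known here is a 3.3-fold higher number from compound 1 to compound 2 (0.52 log units; beyond the scatter), a modest loss. Compound 3 `CC(C)c1onc(-c2c(Cl)cccc2Cl)c1COc1ccc(N(C)Cc2cccc(C(=O)NCCOP(=O)(O)O)c2)c(C(F)(F)F)n1` differs from compound 2 by a group of 7 heavy atoms (2 carbon, 4 oxygen, 1 phosphorus; no ring) in place of a group of 4 heavy atoms (1 carbon, 2 oxygen, 1 sulfur; no ring), on an amide-type nitrogen. That single step bears on the new change only loosely, since the group entering here is unlike either earlier one. A further modest increase is therefore expected, a 1.8-fold higher number from compound 2 to compound 3 (0.24 log units; within the scatter). For compound 3 the estimate in this assay is 35 nM, within a range from 8 nM to 150 nM.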

Compound 3, half-maximal effective concentration: 216 nM
Compound 3: middle estimate off by 6.2-fold (0.79 log units), on the low side; the whole stated range lies below it.
By their numbers in this assay, from the lowest: compound 1; then compound 2; then compound 3.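

In this assay the amide-type nitrogen proves far less accommodating than the first replacement suggested: the phosphorus-bearing group of 7 heavy atoms in place of methylsulfonyl gives an 11-fold higher number from compound 2 to compound 3 (1.03 log units; beyond the scatter) as a large loss. Set against hydroxy on the carbonyl carbon, the change reaches a 36-fold higher number from compound 1 to compound 3 (1.56 log units; beyond the scatter) and so goes well past the modest step seen with methylsulfonyl. No supporting data explain this loss. Open, as far as these compounds go, is how a short chain ending in a hydroxyl or an amine, or a longer chain, would compare on that nitrogen, and so whether the loss follows the chain or its phosphorus-bearing end.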